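Carbonyl substituent variation on the shared core

This account rests on a few compounds, and the source may have more. Where it says the series, first, only, none or still open, it means among the compounds named here.

In a functional assay on HCT-116 cells (Homo sapiens) for inhibition, read by MTT assay, with a stated time of 48 h (on this read-out lower numbers stand for stronger inhibition and higher numbers for weaker inhibition), compound 3 `COc1ccc(CN(C(=O)CO)c2cc(OC)c(OC)c(OC)c2)cc1O` gives 520 nM, the highest of the three numbers; compound 2 `C#CC(=O)N(Cc1ccc(OC)c(O)c1)c1cc(OC)c(OC)c(OC)c1` gives 310 nM and compound 1 `C=C(C)C(=O)N(Cc1ccc(OC)c(O)c1)c1cc(OC)c(OC)c(OC)c1` gives 200 nM. The step of a 2.6-fold higher number from compound 1 to compound 3 (0.41 log units; beyond the scatter) is modest but beyond the scatter, whereas a 1.7-fold higher number from compound 2 to compound 3 (0.22 log units; within the scatter) and a 1.6-fold higher number from compound 1 to compound 2 (0.19 log units; within the scatter) stay within it. Compound 4 `COc1ccc(CN(C(=O)C2CC2)c2cc(OC)c(OC)c(OC)c2)cc1O` differs from compound 3 by cyclopropyl in place of hydroxymethyl on a carbonyl carbon. All three measured steps concern the same place on the carbonyl carbon, so each bears on this change. Because the step of a 2.6-fold higher number from compound 1 to compound 3 (0.41 log units; beyond the scatter) shows the hydroxymethyl of compound 3 carrying the higher number, compound 4 is expected to give a somewhat lower number, an estimated step of a 2.0-fold lower number from compound 3 to compound 4 (0.30 log units; within the scatter). The estimate for compound 4 is 260 nM, with a range from 110 nM to 650 nM.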

Compound 4, half-maximal inhibitory concentration: 49 nM
Compound 4: the middle estimate sits 5.3-fold (0.72 log units) above what was measured, and the stated range ends above it.
By their numbers in this assay, from the lowest: compound 4; then compounds 1, 2 and 3 (each within the scatter of the next, the first and the last beyond it).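

In this assay this carbonyl carbon proves more sensitive to substitution than compounds 1, 2 and 3 alone showed, with cyclopropyl clear of all three groups tested before it (an 11-fold lower number from compound 3 to compound 4 (1.03 log units; beyond the scatter); a 6.3-fold lower number from compound 2 to compound 4 (0.80 log units; beyond the scatter); a 4.1-fold lower number from compound 1 to compound 4 (0.61 log units; beyond the scatter)). Compound 4 is the only one of the four with a ring at this place, and its number is the lowest, beyond the scatter of each of the others. No measurement shown here explains the difference.

Going by these compounds, whether the ring itself matters stays open. A cyclobutyl or an isopropyl group on the same carbonyl carbon would separate ring size from branching.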